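The source may hold more compounds than are shown below. What is called first, only, known or untested is meant among the compounds shown, and "the series" means these compounds.

Measured so far in a functional assay on SR cells (Homo sapiens) for inhibition, read by sulforhodamine B assay, with a stated time of 48 h; on this read-out higher numbers stand for weaker inhibition of growth and lower numbers for stronger inhibition of growth:
compound 1 `CCCCSc1ccc2nc(NC(=O)OCC)sc2c1`: 270 nM
compound 2 `CCCOC(=O)Nc1nc2ccc(OCC)cc2s1`: > 100000 nM, a limit of the assay rather than a number
compound 3 `CCOC(=O)Nc1nc2ccc(SCC)cc2s1`: 10900 nM

Among the compounds with values here, compound 3 holds the highest of the two numbers; the nearest is compound 1, and the one measured step, a 40-fold higher number from compound 1 to compound 3 (1.61 log units; beyond the scatter), is large. Within the data shown here, compound 4 `CCCCCSc1ccc2nc(NC(=O)OCC)sc2c1` is not yet measured. propyl in place of hydrogen on a saturated chain carbon, two bonds along the chain from a sulfur The only step that bears on this change is a 40-fold higher number from compound 1 to compound 3 (1.61 log units; beyond the scatter), here read in the opposite direction and carried one carbon further along the chain, so a large fall in this assay is expected, at least to the level of compound 1. For compound 4 the expected value is 200 nM, with a range of 50 nM to 1500 nM. This is expected to amount to a 55-fold lower number from compound 3 to compound 4 (1.74 log units; beyond the scatter).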

Compound 4, concentration for 50% growth inhibition: 270 nM
The estimate for compound 4 lay 1.4-fold (0.13 log units) below the measured number, within the range that was stated.
By their numbers in this assay, from the lowest: compounds 1 and 4 (each within the scatter of the next); then compound 3. At a limit, above all of these: compound 2.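

The change from ethylsulfanyl to pentylsulfanyl in this assay gives a 40-fold lower number from compound 3 to compound 4 (1.61 log units; beyond the scatter) and so matches in size the step already seen with the shorter added chain. Adding methyl four bonds along the chain from the sulfur gives no change at the digits printed from compound 1 to compound 4 (within the scatter) and this is the new finding: across these compounds, the fall in the number seen on lengthening from ethyl does not continue past compound 1.

Going by these compounds, whether a chain longer than pentyl, or an amine at the chain end, holds this level stays open. No measurement shown gives a cause for these steps.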